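Shortening the Alkoxy Chain from Butyl to Methyl

The compounds below may be only part of what the source reports. "The series", "measured", "known", "first", "only" and "open" are said of these compounds alone.

Of the compounds shown here, three sharing one core have been measured in a functional assay on A2780 cells (Homo sapiens) for antiproliferative activity, read by MTT assay, with a stated time of 3 days; on this read-out lower numbers stand for stronger inhibition and higher numbers for weaker inhibition. Compound 3, `CCCCOC1(c2ccc(Cl)cc2)SC=C(C)n2c1noc2=O`, gives 89000 nM in this assay. Compound 2, `CC/C=C/COC1(c2ccc(Cl)cc2)SC=C(C)n2c1noc2=O`, gives 55000 nM, and the gap a 1.6-fold higher number from compound 2 to compound 3 (0.21 log units; within the scatter) is small. Compound 1, `CCCCCOC1(c2ccc(Cl)cc2)SC=C(C)n2c1noc2=O`, gives > 100000 nM, which is a limit of the assay rather than a number. Compound 4, `COC1(c2ccc(Cl)cc2)SC=C(C)n2c1noc2=O`, has not yet been measured; it differs from compound 3 in that (hydrogen in place of propyl on a saturated chain carbon bound to an oxygen on a saturated carbon).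

The measured step that bears most on this change is an at least 1.1-fold lower number from compound 1 to compound 3 (0.05 log units; that floor lies within the scatter), where hydrogen in place of methyl at the chain end gave a slightly lower number. Swapping the saturated chain for an unsaturated one gave an at least 1.8-fold lower number from compound 1 to compound 2 (0.25 log units; that floor lies within the scatter). Every change seen so far stays close to the scatter, and all numbers sit in a weak range. A larger shortening of the same chain is therefore expected to change little, and the step of a 1.1-fold lower number from compound 3 to compound 4 (0.05 log units; within the scatter) is estimated as no movement beyond the scatter. Compound 4 is expected to give about 80000 nM, likely between 30000 nM and 200000 nM, with a real chance that only a limit is reported.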

Compound 4, half-maximal inhibitory concentration: 166000 nM
For compound 4 the middle estimate is 2.1-fold (0.32 log units) below the measured one; the measured number falls inside the stated range.
By their numbers in this assay, from the lowest: compounds 2, 3 and 4 (each within the scatter of the next, the first and the last beyond it).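

In this assay, cutting the butoxy chain down to methoxy gives a 1.9-fold higher number from compound 3 to compound 4 (0.27 log units; within the scatter), so at this position the shortening brings no gain and no loss that can be told from repeat-to-repeat variation. Set against the unsaturated chain, the same methoxy compound shows a 3.0-fold higher number from compound 2 to compound 4 (0.48 log units; beyond the scatter) and this is the only readable step in the series so far that clears the scatter, although it is a modest one and all the numbers remain weak. Compound 1 carries a limit and not a number, so the step from it to the methoxy compound cannot be read: the limit of > 100000 nM in this assay, at which 1 of the 4 values shown sits.

The compounds shown leave open whether an amine or a carboxylic acid carried on this chain would move the number further than these steps do. They also leave open what a benzyl group in place of the chain would do.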